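From benzyl to oxan-4-yl: one number, two limits

This account rests on a few compounds, and the source may have more. Where it says the series, first, only, none or still open, it means among the compounds named here.

In a functional assay on K562 cells (Homo sapiens), read by thymidine incorporation (a higher number here means a weaker inhibitor, a lower number a stronger inhibitor), compound 1 `c1csc(-c2[nH]cnc3ncnc2-3)c1` gives only a limit of the assay, < 10 ug/mL. Compound 2 `Cn1cnc2c(-c3ccco3)ncnc21` also gives only a limit, < 10 ug/mL. Compound 3 `c1ccc(Cn2cnc3c(-c4ccco4)ncnc32)cc1` is the only one of these with a true number, 59 ug/mL.

Compound 4 `c1coc(-c2ncnc3c2ncn3C2CCOCC2)c1` has oxan-4-yl in place of benzyl on an aromatic nitrogen. The change sits on an aromatic nitrogen of a five-membered aromatic ring, and it removes the phenyl ring of the benzyl group.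

Going by the values given here, one measured step bears on this. Putting phenyl in place of hydrogen on a saturated chain carbon bound to an aromatic nitrogen gave an at least 5.9-fold higher number from compound 2 to compound 3 (0.77 log units; beyond the scatter). The size of that step is only a bound, set by the limit of < 10 ug/mL in this assay, at which 2 of the 3 values shown sit. Compound 4 also lacks that phenyl, but oxan-4-yl still brings a six-membered ring, so only part of the rise seen in an at least 5.9-fold higher number from compound 2 to compound 3 (0.77 log units; beyond the scatter) is expected to be undone. The expected change is a 2.4-fold lower number from compound 3 to compound 4 (0.37 log units; beyond the scatter), towards a stronger inhibitor in this assay, and a single step gives this expectation thin support. For compound 4 the estimated value is 25 ug/mL, with an expected range from 7 ug/mL to 70 ug/mL.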

Compound 4, half-maximal inhibitory concentration: 15 ug/mL
Estimate against measurement, compound 4: 1.7-fold (0.22 log units) above; the range from low to high includes it.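

Going by these compounds alone, the step of a 3.9-fold lower number from compound 3 to compound 4 (0.59 log units; beyond the scatter) is the first at this aromatic nitrogen with a true number at both ends, so its size is measured and is not a bound. In this assay it shows that a six-membered ring on this nitrogen does not by itself bring the number up to that of compound 3: the non-aromatic oxan-4-yl ring, with its one oxygen, reads lower than benzyl. Against the small methyl group the picture stays unresolved, with an at least 1.5-fold higher number from compound 2 to compound 4 (0.17 log units; that floor lies within the scatter), and that step can only be read as a floor, so methyl and oxan-4-yl cannot be put in order, as much of this short series rests on a limit: the limit of < 10 ug/mL in this assay, at which 2 of the 4 values shown sit.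

As far as these compounds go, what remains open is whether the lower number comes from losing the aromatic ring or from gaining the ring oxygen, a question that cyclohexyl on the same nitrogen would separate. Also open, from the compounds shown here alone, is how an amine such as piperidin-4-yl, or a longer open chain such as butyl, would read at this position in this assay.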